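From compound 2 to compound 3 at the assay limit

This account rests on a few compounds, and the source may have more. Where it says the series, first, only, none or still open, it means among the compounds named here.

Compound 1 `O=C(CCCCCCCc1ccccc1)N1CCCCC1`: > 100000 nM
Compound 2 `O=C(CCCCCCCCCc1ccccc1)N1CCCCC1`: > 100000 nM

In a functional assay on PANC-1 cells (Homo sapiens) for cytotoxicity, read by WST assay, with a stated time of 24 h (on this read-out lower numbers stand for stronger inhibition and higher numbers for weaker inhibition), compound 1 gives > 100000 nM, which is a limit and not a number.

Compound 2 likewise gives only a limit, > 100000 nM.

Neither compound has a number to compare, and the picture so far is simply (the limit of > 100000 nM in this assay, at which 2 of the 2 values shown sit). Within the data shown here, no step between measured compounds is available, so no size of change has been seen in this assay.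

The next compound is compound 3 `O=C(CCCCCCCCc1cccc(F)c1)N1CCCCC1`. Its change from compound 2 is 3-fluorophenyl in place of benzyl on a saturated chain carbon, eight bonds along the chain from a carbonyl carbon.

The expectation in this assay rests on compound 2 and its limit of > 100000 nM. A report of only a limit is again the likeliest outcome. The expected step is a number no higher from compound 2 to compound 3 (the limit leaves the size open).

For compound 3 the estimate is 100000 nM, with an expected range from 40000 nM to 200000 nM.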

Compound 3, half-maximal inhibitory concentration: > 100000 nM
Compound 3 was reported as a limit; the forecaster's own chance of this, stated with the estimate: 75%; the middle value sits exactly at the limit.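

Compound 3, like compound 2, is reported in this assay only as a limit, so no step can be read between the two: the limit of > 100000 nM in this assay, at which 3 of the 3 values shown sit.

The compounds shown leave open what number any of them would reach in this assay, and whether 3-fluorophenyl in place of benzyl changes that number at all.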